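This account rests on a few compounds, and the source may have more. Where it says the series, first, only, none or still open, it means among the compounds named here.

In a functional assay on HepG2 cells (Homo sapiens) for antiproliferative activity, read by colorimetric assay and MTT assay, with a stated time of 48 h (a lower number here means a stronger inhibitor, a higher number a weaker inhibitor), the measured compounds stand as follows:

Compound 1 `O=C(NS(=O)(=O)c1ccc(Br)cc1)c1ccncc1` gives 6300 nM.
Compound 2 `Cc1ccc(S(=O)(=O)NC(=O)c2ccncc2)cc1` gives 20200 nM.
Compound 3 `O=C(NS(=O)(=O)c1ccc(Br)cc1)c1ccccn1` gives 5000 nM.

Compound 4 `Cc1ccc(S(=O)(=O)NC(=O)c2ccccn2)cc1` has not yet been measured in this assay. It differs from compound 3 by one change: methyl in place of bromo on an aromatic carbon The same change already occurs once among the measured compounds, going from compound 1 to compound 2: methyl in place of bromo on an aromatic carbon There it made a 3.2-fold higher number from compound 1 to compound 2 (0.51 log units; beyond the scatter). The place is described in identical words for both pairs, so this is the same change, not merely the same kind. The two cores differ as follows: pyridin-2-yl in place of pyridin-4-yl on a carbonyl carbon That swap gave a 1.3-fold lower number from compound 1 to compound 3 (0.10 log units; within the scatter), so the two cores sit close together. Going by the values given here, only one earlier example of the change exists, and the expectation rests on it alone. Compound 4 is expected to land at 16000 nM, with a likely span from 8000 nM to 32000 nM. The expected step is a 3.2-fold higher number from compound 3 to compound 4 (0.51 log units; beyond the scatter), chosen to match the earlier one. This rests on compound 3 giving 5000 nM together with a 3.2-fold higher number from compound 1 to compound 2 (0.51 log units; beyond the scatter).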

Compound 4, half-maximal inhibitory concentration: 12100 nM
Estimate against measurement, compound 4: 1.3-fold (0.12 log units) above; the measured number falls inside the stated range.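

In this assay, methyl in place of bromo gave a 2.4-fold higher number from compound 3 to compound 4 (0.38 log units; beyond the scatter), so the weaker result seen on the core of compound 1 appears again on the core of compound 3, and the two steps agree: the same change on two cores in this assay, a 3.2-fold higher number (0.51 log units; beyond the scatter) from compound 1 to compound 2 and a 2.4-fold higher number (0.38 log units; beyond the scatter) from compound 3 to compound 4, 1.3-fold (0.12 log units) apart, within the scatter of two such steps. Pyridin-2-yl in place of pyridin-4-yl gave a 1.7-fold lower number from compound 2 to compound 4 (0.22 log units; within the scatter), which matches the earlier example of that change: the same change on two cores in this assay, a 1.3-fold lower number (0.10 log units; within the scatter) from compound 1 to compound 3 and a 1.7-fold lower number (0.22 log units; within the scatter) from compound 2 to compound 4, 1.3-fold (0.12 log units) apart, within the scatter of two such steps. Together, these results show that each change carried over between two closely related cores, but they do not show that it would carry to a more different core, and they do not explain why methyl gives the higher number.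

Among the compounds shown, only bromo and methyl occupy that place on the carbon-only ring, so the effect of a chloro group, a methoxy group or a carboxylic acid there remains open. On the carbonyl carbon only the two pyridinyl groups appear, leaving open what a phenyl ring or a longer chain would do.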